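Swapping an Ester for an Ether on the Shared Core

This account rests on a few compounds, and the source may have more. Where it says the series, first, only, none or still open, it means among the compounds named here.

Measured so far:
compound 1, `CCCCC(O)CC(=O)O[C@H](CC=C(C)C)C1=CC(=O)c2c(O)ccc(O)c2C1=O`, 72200 nM
compound 2, `CC(C)=CC[C@@H](OC[C@@H](C)O)C1=CC(=O)c2c(O)ccc(O)c2C1=O`, 22500 nM
compound 3, `CC[C@@](C)(O)CC(=O)O[C@H](CC=C(C)C)C1=CC(=O)c2c(O)ccc(O)c2C1=O`, 17900 nM

All three compounds share the same core and differ only in the group carried on an oxygen on a saturated carbon. In a functional assay on HeLa cells (Homo sapiens) for cytotoxicity, read by MTT assay (a higher number here means a weaker inhibitor, a lower number a stronger inhibitor), compound 3 gives 17900 nM, the lowest of the three numbers, though its gap to compound 2 is within the scatter; only compound 1 stands clearly apart, as a 4.0-fold lower number from compound 1 to compound 3 (0.61 log units; beyond the scatter) shows.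

Compound 4, `COC(C)CO[C@H](CC=C(C)C)C1=CC(=O)c2c(O)ccc(O)c2C1=O`, is the next step from compound 3: 2-methoxypropyl in place of (2-hydroxy-2-methylbutyl)carbonyl on an oxygen on a saturated carbon. The ester and its hydroxyl group leave, and a short ether chain with a methoxy group enters.

The most telling measured step is a 1.3-fold lower number from compound 2 to compound 3 (0.10 log units; within the scatter), where a hydroxyl-bearing ether and a hydroxyl-bearing ester gave numbers within the scatter of each other. Among the measured compounds shown here, compound 4 keeps an ether like compound 2 but has no hydrogen-bond donor, a change no measured pair covers. The expectation is therefore a step of about a 1.4-fold higher number from compound 3 to compound 4 (0.15 log units; within the scatter), little beyond the scatter. Compound 4 is estimated at 25000 nM, between 8000 nM and 80000 nM.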

Compound 4, half-maximal inhibitory concentration: 53400 nM
Estimate against measurement, compound 4: 2.1-fold (0.33 log units) below, within the range that was stated.
By their numbers in this assay, from the lowest: compounds 3 and 2 (each within the scatter of the next); then compounds 4 and 1 (each within the scatter of the next).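

In this assay the closest comparison is a 2.4-fold higher number from compound 2 to compound 4 (0.38 log units; beyond the scatter), where the chain stays an ether and 1-methoxyethyl replaces 1-hydroxyethyl, so at this position the hydroxyl-to-methoxy change alone moves the number beyond the scatter. The larger swap gives a 3.0-fold higher number from compound 3 to compound 4 (0.47 log units; beyond the scatter), whereas a 1.4-fold lower number from compound 1 to compound 4 (0.13 log units; within the scatter) leaves the two compounds within the scatter of each other, so neither an ester nor an ether at this place goes with one level of the number: compounds 2 and 3 pair up across that divide, and so do compounds 1 and 4, while keeping a hydroxyl does not suffice either, as compound 1 goes against that pattern. No supporting measurement here accounts for the shift seen with the methoxy group.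

Still open, on these data alone, is how an amine or a carboxylic acid would read in place of the methoxy group on this short ether chain. Also open, as far as these compounds go, is whether a longer ether chain such as 2-hydroxyhexyl would stay with compound 2 or move toward compound 1, since the ester pair alone cannot tell what chain length does on an ether.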